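This account rests on a few compounds, and the source may have more. Where it says the series, first, only, none or still open, it means among the compounds named here.

Compound 2, `CCc1cccc(NC(=O)N[C@@H](C)c2ccccc2)c1`, was tested in an ADME assay on the whole organism with Oryza sativa as the target, tested at 0.1 uM (on this read-out lower numbers stand for a stronger effect and higher numbers for a weaker effect at the one concentration tested), and gave 100%. Among the three numbers measured so far this is the top one, yet the others lie close: compound 3, `CCCCc1ccc(NC(=O)N[C@@H](C)c2ccccc2)cc1`, gave 98%, and compound 1, `CCc1cccc(NC(=O)N[C@H](C)c2ccccc2)c1`, gave 97%, both within the scatter of compound 2. For the measured compounds named here, the only step measured between compounds that differ in one place is a number 3 percentage points higher from compound 1 to compound 2 (within the scatter), and because the fact that compounds 1 and 2 differ only in the configuration as drawn this step says nothing about swapping one group for another.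

Compound 4, `C[C@H](NC(=O)Nc1cccc(F)c1)c1ccccc1`, has not been measured yet. Compared with compound 2 it shows (fluoro in place of ethyl on an aromatic carbon). Going by the values given here, no measured step concerns an exchange of this kind, and compound 3 carries a butyl group at another position without its number leaving the scatter of compound 2. With all three known numbers sitting close to the weak end of the read-out, there is no sign in these data that the change should push the number out of the scatter in either direction. For compound 4 the expected value is therefore 97%, with a range from 85% to 100%. This amounts to an expected step of a number 3 percentage points lower from compound 2 to compound 4 (within the scatter), which is no change beyond the scatter.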

Compound 4, a percentage reported as activity, at one concentration (the size of the read-out at that concentration, not a potency): 97%
For compound 4 middle estimate and measured number coincide at the digits printed; the measured number falls inside the stated range.
By their numbers in this assay, from the lowest: compounds 1, 4, 3 and 2 (each within the scatter of the next).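

In this assay the exchange of ethyl for fluoro on an aromatic carbon, meta to a large group, comes with a number 3 percentage points lower from compound 2 to compound 4 (within the scatter) and is the only step shown so far that swaps one group for another. It shows that at this place a group of 2 carbon atoms can give way to a single fluorine atom without the number leaving the scatter, so this smaller group and the ethyl group cannot be told apart on this read-out. Nothing known about these compounds explains this result, since the only available fact concerns configuration and not this exchange.

What the compounds shown leave open is whether any group on this aromatic carbon can move the number beyond the scatter, for example an amine, a carboxylic acid or a longer chain such as hexyl. Also open, going by these compounds, is whether fluoro gives a similar number with the other configuration as drawn at the saturated chain carbon, as the exchange has been read with only one configuration.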